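Cinnamate esters of a trimethoxyphenyl allyl alcohol: whole-animal notes

The compounds below may be only part of what the source reports. "The series", "measured", "known", "first", "only" and "open" are said of these compounds alone.

Compound 1 `COc1cc(OC)c(OC)cc1/C=C/COC(=O)/C=C/c1ccccc1C(F)(F)F` and compound 2 `COc1cc(OC)c(OC)cc1/C=C/COC(=O)/C=C/c1cc(OC)c(OC)c(OC)c1` share the same core and differ only in the aryl group on the cinnamate side. In a functional assay on the whole organism (strain Kunming) with Mus musculus as the target, with a stated time of 0.5 h, at a dose of 100 mg/kg by the intraperitoneal route (a higher number here means a weaker effect of the compound at the dose given, a lower number a stronger effect), compound 1 gives 100%, and compound 2 gives 100%. Compound 1 thus stands level with compound 2 at the digits printed, the gap between them lying within the scatter, so no order between the two can be stated.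

Compound 3 `COc1cc(OC)c(OC)cc1/C=C/COC(=O)/C=C/c1ccc(Cl)cc1` is not yet measured in this assay. It differs from compound 1 by 4-chlorophenyl in place of 2-(trifluoromethyl)phenyl on a double-bonded chain carbon bound to a double-bonded chain carbon. For the measured compounds named here, nothing among the measured pairs tells how this position responds to such a change; the only comparison in hand, compound 1 against compound 2, shows two quite different aryl groups giving the same read-out. On that basis the step from compound 1 to compound 3 in this assay is expected to be small, if anything a slight fall, and most likely to stay within the scatter, an expected step of a number 5 percentage points lower from compound 1 to compound 3 (within the scatter). Compound 3 is therefore estimated at 95%, with a range from 75% to 100%.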

Compound 3, a percentage reported as activity, at one dose (the size of the read-out at that dose, not a potency): 100%
The estimate for compound 3 lay 5 percentage points below the measured number; low and high end bracket the measured number.
By their numbers in this assay, from the lowest: compounds 1, 2 and 3 (each within the scatter of the next).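

In this assay, 4-chlorophenyl in place of 2-(trifluoromethyl)phenyl on a double-bonded chain carbon bound to a double-bonded chain carbon gives no change at the digits printed from compound 1 to compound 3 (within the scatter). The change swaps the kind of halogen on the aryl group, shifts where it sits on the ring and goes from 10 heavy atoms to 7, yet the read-out at the dose given does not separate the two compounds, so this position now has a single-place step showing that this exchange leaves the read-out flat. Nothing in hand accounts for this flat result.

The compounds shown leave open whether any group at this position can move the read-out at all, for example a phenyl ring carrying an amine or a carboxylic acid, or a pyridine ring in place of the phenyl ring. On these data alone, it also remains open whether a change elsewhere in the molecule, such as a longer chain between the ester oxygen and the trimethoxyphenyl ring, would separate compounds that this aryl position does not.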